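Swapping Bromo for Methoxy: Expected Vero Cell Toxicity

The compounds below may be only part of what the source reports. "The series", "measured", "known", "first", "only" and "open" are said of these compounds alone.

Compound 2 `CCOC(=O)c1cc(-c2cccc(OCc3cccc(Br)c3)c2)on1` was examined in an ADME assay on Vero cells (Chlorocebus sabaeus) for cytotoxicity, with a stated time of 72 h; on this read-out higher numbers stand for weaker inhibition and lower numbers for stronger inhibition. In that assay compound 2 gives > 128000 nM, which is a limit of the assay rather than a measured number. Compound 1 `CCOC(=O)c1cc(-c2cccc(OCc3cccc(C(F)(F)F)c3)c2)on1` gives > 128000 nM, also a limit. Compound 3 `CCOC(=O)c1cc(-c2cccc(OCc3cccc(N)c3)c2)on1` gives > 128000 nM, a limit too. Because of the limit of > 128000 nM in this assay, at which 3 of the 3 values shown sit, the steps a step that the two limits leave unreadable from compound 1 to compound 2, a step that the two limits leave unreadable from compound 1 to compound 3 and a step that the two limits leave unreadable from compound 2 to compound 3 cannot be read. Compound 4 `CCOC(=O)c1cc(-c2cccc(OCc3cccc(OC)c3)c2)on1` differs from compound 2 by methoxy in place of bromo on an aromatic carbon. Among the measured compounds shown here, all three measured values sit at the same limit, so none of the measured steps shows a readable direction or size that could carry over to this change. The step from compound 2 to compound 4 is expected to be a number no higher from compound 2 to compound 4 (the limit leaves the size open), meaning no readable change. Compound 4 is therefore expected to give 128000 nM, within 64000 nM and 256000 nM, most likely again reported only as a limit.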

Compound 4, half-maximal inhibitory concentration: > 128000 nM
Compound 4 ended at the assay's limit (the forecaster's own chance of this, stated with the estimate: 85%); the middle value lies on the limit itself.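

No step between compound 4 and compound 1, compound 2 or compound 3 can be read, since each result is a limit and not a number: the limit of > 128000 nM in this assay, at which 4 of the 4 values shown sit.

The compounds shown leave open whether trifluoromethyl, bromo, amino and methoxy differ at all in this assay.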